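Moving the ring attachment point of a small saturated amine

A few compounds are considered here, and "the series" means these few. Any claim that something is new, unique, unknown or untested is made for them only; others in the source may bear on it.

Compound 1, `COc1cc(Br)cc(-c2noc(C3CCCCN3Cc3ccccc3)n2)c1OC`, gives 5.81 in a physicochemical assay for lipophilicity; on this read-out lower numbers stand for lower lipophilicity and higher numbers for higher lipophilicity.
Compound 2, `COc1cc(Br)cc(-c2noc(C3CCN(C)CC3)n2)c1OC`, gives 3.86 in this assay.

Of these two numbers, compound 2 stands lowest, and compound 1 sits well beyond the scatter above it. Compound 3, `COc1cc(Br)cc(-c2noc(C3CCCCN3C)n2)c1OC`, has not yet been measured. It differs from compound 2 in one place: 1-methylpiperidin-2-yl in place of 1-methylpiperidin-4-yl on an aromatic carbon. For the measured compounds named here, no measured pair shows such a change, so the size of this step is not known from the data. With the same atoms present in both, a step of a number 0.04 log units higher from compound 2 to compound 3 (within the scatter) is expected, lying within the usual scatter. Compound 3 is therefore expected to give about 3.9, most likely between 3.5 and 4.3.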

Compound 3, partition coefficient: 4.21
Compound 3: the middle estimate sits 0.31 log units below what was measured; the measured number falls inside the stated range.
By their numbers in this assay, from the lowest: compound 2; then compound 3; then compound 1.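

Changing only the attachment point, with the same atoms present, is enough to shift the number in this assay: 1-methylpiperidin-2-yl in place of 1-methylpiperidin-4-yl gives a number 0.35 log units higher from compound 2 to compound 3 (beyond the scatter). With the attachment kept, hydrogen in place of phenyl on the saturated chain carbon bound to the amine nitrogen in the ring gives a much larger step, a number 1.60 log units lower from compound 1 to compound 3 (beyond the scatter). Nothing given here explains why either step has its size. From the compounds shown here alone, whether the attachment change would give a similar step with an ethyl group in place of the methyl on that amine nitrogen stays open.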